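Nitrofuran Ester in Place of Methylbenzoate on Compound 2

The source may hold more compounds than are shown below. What is called first, only, known or untested is meant among the compounds shown, and "the series" means these compounds.

This account follows three measured compounds and one unmeasured one in a functional assay on MDA-MB-231 cells (Homo sapiens) for antiproliferative activity, read by MTT assay, with a stated time of 72 h; on this read-out higher numbers stand for weaker inhibition and lower numbers for stronger inhibition. Compound 1 `CC1=CC[C@H]2[C@@H]1CC=C(C)[C@@H](CCC1=C(C)CC[C@@H]3OC(C)(C)[C@@H](O)CC[C@@]13C)C2(C)C` reaches only the limit of the measurement and is recorded as > 50000 nM. Compound 2 `CC1=CC[C@H]2[C@H](CC[C@]2(C)O)C(C)(C)[C@@H]1CC[C@H]1[C@]2(C)CC[C@H](OC(=O)c3ccc(C)cc3)C(C)(C)O[C@H]2CC[C@@]1(C)O` gives 33400 nM in this assay. Compound 3 `CC1=CC[C@H]2[C@@H]1CC=C(C)[C@@H](CC[C@H]1[C@]3(C)CC[C@H](OC(=O)c4ccc(Cl)cc4)C(C)(C)O[C@H]3CC[C@@]1(C)O)C2(C)C` gives 12700 nM in this assay. Among the two numbers recorded, compound 2 stands highest, and compound 3 sits below it by a gap that lies beyond the usual scatter of repeated measurements.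

Compound 4 `CC1=CC[C@H]2[C@H](CC[C@]2(C)O)C(C)(C)[C@@H]1CC[C@H]1[C@]2(C)CC[C@H](OC(=O)c3ccc([N+](=O)[O-])o3)C(C)(C)O[C@H]2CC[C@@]1(C)O` has not yet been measured in this assay. It differs from compound 2 in one place: 5-nitrofuran-2-yl in place of 4-methylphenyl on a carbonyl carbon. Among the measured compounds shown here, no measured pair in this set carries the same change, so its direction cannot be read from the data. Compound 4 is expected to give 25000 nM in this assay. Its estimated range runs from 8000 nM to 80000 nM. The expected step of a 1.3-fold lower number from compound 2 to compound 4 (0.13 log units; within the scatter) is judged to lie within the scatter, with no change beyond it anticipated.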

Compound 4, half-maximal inhibitory concentration: 11100 nM
Compound 4: the middle estimate sits 2.3-fold (0.35 log units) above what was measured; low and high end bracket the measured number.
By their numbers in this assay, from the lowest: compounds 4 and 3 (each within the scatter of the next); then compound 2. At a limit, above all of these: compound 1.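

In this assay, the group on the carbonyl carbon of this ester proves able to shift the read-out: 5-nitrofuran-2-yl in place of 4-methylphenyl gives a 3.0-fold lower number from compound 2 to compound 4 (0.48 log units; beyond the scatter). Among the compounds shown here, this is the first step in the set that can be read, and it shows that the position responds to a change of aromatic ring and its substituent, with the five-membered ring retained as a workable replacement. Nothing shown here gives a reason for the step, which rests on this single pair.

As far as these compounds go, it remains open whether the furan ring or the nitro group carries the step, a question that a plain furan-2-yl or a 4-nitrophenyl on the same carbonyl carbon would separate. Also open, from the compounds shown here alone, is how an aminophenyl group or a saturated alkyl chain would fare at this place.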